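Replacing 4-ethoxyphenyl with 3,4-difluorophenyl on the saturated ring carbon

This account rests on a few compounds, and the source may have more. Where it says the series, first, only, none or still open, it means among the compounds named here.

Going by the values given here, in a functional assay on MCF7 cells (Homo sapiens) for cytotoxicity, read by WST assay, with a stated time of 72 h (on this read-out lower numbers stand for stronger inhibition and higher numbers for weaker inhibition), compound 1 `O=C1Nc2c(ccc(F)c2F)C1(c1ccc(O)cc1)c1ccc(F)cc1` gives 2.6 nM and compound 2 `CCOc1ccc(C2(c3ccc(O)cc3)C(=O)Nc3c2ccc(F)c3F)cc1` gives 11 nM, the higher of the two numbers so far. The next structure, compound 3 `O=C1Nc2c(ccc(F)c2F)C1(c1ccc(O)cc1)c1ccc(F)c(F)c1`, has 3,4-difluorophenyl in place of 4-ethoxyphenyl on a saturated ring carbon. Among the compounds with values here, the only measured step bearing on this is a 4.2-fold higher number from compound 1 to compound 2 (0.63 log units; beyond the scatter), for ethoxy in place of fluoro on an aromatic carbon. Reversing that modest step points to a lower number of similar size in this assay, although no measured step covers the second fluorine. The expected step is a 2.8-fold lower number from compound 2 to compound 3 (0.44 log units; beyond the scatter). The estimate for compound 3 is 4 nM, with an expected range of 1.5 nM to 11 nM.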

Compound 3, half-maximal inhibitory concentration: 7.8 nM
Compound 3: the middle estimate sits 2.0-fold (0.29 log units) below what was measured; the range from low to high includes it.
By their numbers in this assay, from the lowest: compound 1; then compounds 3 and 2 (each within the scatter of the next).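

In this assay, exchanging these two aryl groups on the saturated ring carbon gives no readable difference (a 1.4-fold lower number from compound 2 to compound 3 (0.15 log units; within the scatter)). The added fluorine gives a step beyond the scatter (a 3.0-fold higher number from compound 1 to compound 3 (0.48 log units; beyond the scatter)), so compound 1 stands apart from both compound 2 and compound 3 among the aryl groups shown. No evidence on hand explains either step.

Still open, as far as these compounds go, is whether an amine, a carboxylic acid or a chain longer than ethoxy on this aryl group would fall nearer compound 1 or nearer compound 2 and compound 3.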